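The source may report more compounds than this note shows. Statements on the series, on what has been measured and on what is new or still open speak of the compounds shown alone.

Measured so far in a functional assay on K562 cells (Homo sapiens) for antiproliferative activity, read by MTT assay, with a stated time of 48 h; on this read-out lower numbers stand for stronger inhibition and higher numbers for weaker inhibition:

compound 1 `CN1C(=O)C2(C(C#N)=C(N)Oc3cc4oc(-c5ccccc5)cc(=O)c4c(O)c32)c2ccccc21` gives > 50000 nM, a limit of the assay.
compound 2 `CN1C(=O)C2(C(C#N)=C(N)Oc3cc4oc(-c5ccccc5)cc(=O)c4c(O)c32)c2cccc(Cl)c21` gives 41400 nM.
compound 3 `Cc1ccc2c(c1)C1(C(=O)N2Cc2ccccc2)C(C#N)=C(N)Oc2cc3oc(-c4ccccc4)cc(=O)c3c(O)c21` gives > 50000 nM, a limit of the assay.

Within the data shown here, compound 2 holds the only number in the set; the other two entries are limits, as summarised in the limit of > 50000 nM in this assay, at which 2 of the 3 values shown sit. Among the measured compounds shown here, the one step between measured compounds that differ in a single place is an at least 1.2-fold lower number from compound 1 to compound 2 (0.08 log units; that floor lies within the scatter), a chloro in place of a hydrogen on an aromatic carbon, and its floor stays within the scatter.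

Compound 4 `N#CC1=C(N)Oc2cc3oc(-c4ccccc4)cc(=O)c3c(O)c2C12C(=O)Nc1c(Cl)cccc12` is yet to be measured in this assay. It differs from compound 2 by hydrogen in place of methyl on an amide-type nitrogen in a ring. For the measured compounds named here, no measured pair in the set shares this change: the step from compound 1 to compound 2 concerns a substituent on an aromatic carbon, and compound 3 differs from compound 2 in more than one place. The values therefore give no direction for the loss of the methyl on the ring nitrogen. No step beyond the scatter is expected, so the estimated step is no change at the digits printed from compound 2 to compound 4 (within the scatter). Compound 4 is estimated at 41400 nM, within 14000 nM to 125000 nM, with a fair chance that only a limit is returned.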

Compound 4, half-maximal inhibitory concentration: 37500 nM
The estimate for compound 4 lay 1.1-fold (0.04 log units) above the measured number, and the stated range covers the measured number.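

In this assay the series now holds a step at the amide-type nitrogen in a ring: a 1.1-fold lower number from compound 2 to compound 4 (0.04 log units; within the scatter). On this one pair, with the chloro group kept, exchanging the methyl for hydrogen leaves the read-out within the scatter, so neither the methyl nor the amide hydrogen is shown to matter at this position. Compound 1 and compound 3 remain limits, so the only numbers in the set belong to the two chloro-bearing compounds, and no trend can be drawn from them: the limit of > 50000 nM in this assay, at which 2 of the 4 values shown sit.

Open, as far as these compounds go, is whether a different group on this ring nitrogen, such as a longer chain ending in a carboxylic acid, would move the number beyond the scatter; compound 3 differs from compound 2 in more than one place and gives no reading of this position. Also open is whether the absence of a step at this nitrogen would hold on a compound with a much lower number, and the two numbers shown cannot settle that.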